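The source may hold more compounds than are shown below. What is called first, only, known or untested is meant among the compounds shown, and "the series" means these compounds.

Of the compounds shown here, three sharing one core have been measured in a functional assay on EOL1 cells (Homo sapiens) for inhibition, read by fluorescence, with a stated time of 72 h; a lower number here means a stronger inhibitor of growth, a higher number a weaker inhibitor of growth. Compound 1 (`COc1ccc(Nc2nc(N[C@H]3CC[C@H](N)CC3)nc3c2ncn3CCC(C)C)c(OC)c1`), with a 2,4-dimethoxyphenyl on the nitrogen, gives 630 nM. Compound 2 (`CC(C)CCn1cnc2c(Nc3ccc(Cl)cc3)nc(N[C@H]3CC[C@H](N)CC3)nc21`), with a 4-chlorophenyl there, gives 90 nM. Compound 3 (`CC(C)CCn1cnc2c(Nc3ccccc3)nc(N[C@H]3CC[C@H](N)CC3)nc21`), with an unsubstituted phenyl, gives 10 nM, the lowest of the three numbers and clearly separated from both others.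

Compound 4 (`CC(C)CCn1cnc2c(Nc3cccc(O)c3)nc(N[C@H]3CC[C@H](N)CC3)nc21`) departs from compound 3 in one place, with hydroxy in place of hydrogen on an aromatic carbon, meta to a large group (hydroxy in place of hydrogen on an aromatic carbon). The nearest measured precedent is the chloro-to-hydrogen change, a 9.0-fold lower number from compound 2 to compound 3 (0.95 log units; beyond the scatter), a modest step beyond the scatter. The change from 2,4-dimethoxyphenyl to phenyl, a 63-fold lower number from compound 1 to compound 3 (1.80 log units; beyond the scatter), is a large step in the same direction. Within the data shown here, both substituted compounds thus stand higher than compound 3, though no measured compound carries a hydroxy group, and the two precedents differ from this change in group and place.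

A modest rise in this assay is therefore expected, closer in size to the chloro step than to the dimethoxy one. The expected change is a 3.0-fold higher number from compound 3 to compound 4 (0.48 log units; beyond the scatter). The estimated value for compound 4 is 30 nM, with an expected range from 8 nM to 110 nM.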

Compound 4, concentration for 50% growth inhibition: 60 nM
Compound 4: middle estimate off by 2.0-fold (0.30 log units), on the low side; the range from low to high includes it.
By their numbers in this assay, from the lowest: compound 3; then compounds 4 and 2 (each within the scatter of the next); then compound 1.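

In this assay, hydroxy in place of hydrogen on an aromatic carbon, meta to a large group, gives a clear rise (a step of a 6.0-fold higher number from compound 3 to compound 4 (0.78 log units; beyond the scatter)), so a single small group at this new place on the phenyl also leaves the number above that of compound 3, as the chloro and dimethoxy groups did at their own places. The 3-hydroxyphenyl and 4-chlorophenyl groups cannot be told apart here (a 1.5-fold lower number from compound 2 to compound 4 (0.18 log units; within the scatter)), while the 3-hydroxyphenyl group stands well clear of the 2,4-dimethoxyphenyl group (an 11-fold lower number from compound 1 to compound 4 (1.02 log units; beyond the scatter)). Nothing at hand explains why any of these groups on the phenyl gives a higher number than the unsubstituted ring.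

On these data alone, it remains open whether any group on this phenyl can match or better the unsubstituted ring of compound 3, for instance an amine, a carboxylic acid or a single methoxy group. As far as these compounds go, it is equally open whether the hydroxy group on a different carbon of the ring would read differently from compound 4, so place and group cannot yet be separated.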